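The source may hold more compounds than are shown below. What is called first, only, known or untested is meant among the compounds shown, and "the series" means these compounds.

Compound 1 `Cc1ccccc1C(=O)Nc1cccc(/C=C/C(=O)c2nc3ccccc3[nH]2)c1` — in a functional assay on HCT-116 cells (Homo sapiens) for antiproliferative activity, read by MTT assay, with a stated time of 48 h (on this read-out lower numbers stand for stronger inhibition and higher numbers for weaker inhibition), compound 1 gives 1870 nM
Compound 2 `Cc1cccc(C(=O)Nc2cccc(/C=C/C(=O)c3nc4ccccc4[nH]3)c2)c1` — in this assay compound 2 gives 1420 nM

On the two numbers in this assay, compound 2 stands alongside compound 1 rather than apart from it: the step of a 1.3-fold lower number from compound 1 to compound 2 (0.12 log units; within the scatter) lies within the usual scatter, so the two compounds cannot be told apart on this read-out. Compound 3 `O=C(/C=C/c1cccc(NS(=O)(=O)c2ccccc2Cl)c1)c1nc2ccccc2[nH]1` has not yet been measured. It differs from compound 2 in one place: (2-chlorophenyl)sulfonyl in place of (3-methylphenyl)carbonyl on a nitrogen on an aromatic ring. Among the measured compounds shown here, the only measured step, a 1.3-fold lower number from compound 1 to compound 2 (0.12 log units; within the scatter), moved a methyl around the phenyl on a carbonyl carbon and kept the carbonyl itself; the step to compound 3 instead removes the (3-methylphenyl)carbonyl altogether and brings in a (2-chlorophenyl)sulfonyl on the nitrogen. For the measured compounds named here, no measured step bears directly on such a change, so no step beyond the scatter is expected, but with wide uncertainty. Compound 3 is estimated at 1600 nM in this assay, within 400 nM to 6500 nM, an expected step of a 1.1-fold higher number from compound 2 to compound 3 (0.05 log units; within the scatter).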

Compound 3, half-maximal inhibitory concentration: 987 nM
Compound 3: middle estimate off by 1.6-fold (0.21 log units), on the high side, within the range that was stated.
By their numbers in this assay, from the lowest: compounds 3, 2 and 1 (each within the scatter of the next).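

On the nitrogen on an aromatic ring, (2-chlorophenyl)sulfonyl in place of (3-methylphenyl)carbonyl gives a 1.4-fold lower number from compound 2 to compound 3 (0.16 log units; within the scatter) in this assay and (2-chlorophenyl)sulfonyl in place of (2-methylphenyl)carbonyl gives a 1.9-fold lower number from compound 1 to compound 3 (0.28 log units; within the scatter). This shows that the position can carry a sulfonyl as well as a carbonyl with no step beyond the scatter, so compounds 1, 2 and 3 cannot be told apart on this read-out. Nothing available bears on the reason for this result.

Going by these compounds, the exchange alters the carbonyl, the ring substituent and its place together, so what each contributes on its own remains open. Also open, on these data alone, is how the read-out would respond at this nitrogen to a phenyl carrying a carboxylic acid or to a longer alkyl chain.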